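A few compounds are considered here, and "the series" means these few. Any claim that something is new, unique, unknown or untested is made for them only; others in the source may bear on it.

Measured so far:
- compound 1 `CCCCOC(=O)Nc1cc2nc(C3CCCCC3)[nH]c2cc1N(CCC)CCC` in an ADME assay on Vero cells (Chlorocebus sabaeus) for cytotoxicity, read by resazurin assay, with a stated time of 3 days; a higher number here means a weaker inhibitor, a lower number a stronger inhibitor: > 100 ug/mL
- compound 2 `CCCCOC(=O)Nc1cc2nc(C3CCCCC3)[nH]c2cc1N(C)CCN(C)C` in this assay: > 100 ug/mL

Both values are limits of this assay rather than numbers. Compound 1 gives > 100 ug/mL, a limit. Compound 2 gives > 100 ug/mL, likewise a limit. The step that the two limits leave unreadable from compound 1 to compound 2 therefore cannot be read because both values sit at the limit of > 100 ug/mL in this assay, at which 2 of the 2 values shown sit. Within the data shown here, compound 2 thus stands at the limit of this assay, with no number attached and no measured compound that it can be compared with in size.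

Compound 3 `CCCCOC(=O)Nc1cc2nc(C3CCCCC3)[nH]c2cc1N(CC)CCN(CC)CC` carries (2-(diethylamino)ethyl)(ethyl)amino in place of (2-(dimethylamino)ethyl)(methyl)amino on an aromatic carbon. Among the measured compounds shown here, the only measured step that bears on this change is the one from compound 1 to compound 2, and its size is not readable. No direction beyond the scatter can be drawn from it. Compound 3 is expected to remain at or near the limit, an estimate of 120 ug/mL with a range of 50 ug/mL to 300 ug/mL. The expected step that the limit leaves unreadable from compound 2 to compound 3 is nil beyond the scatter.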

Compound 3, half-maximal inhibitory concentration: > 50 ug/mL
Compound 3 gave a limit, no number; the forecaster's own chance of this, stated with the estimate: 75%; the middle value does not contradict the limit.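

In this assay compound 3 gives > 50 ug/mL as a limit and not a number. Among these compounds, no step among compound 1, compound 2 and compound 3 can be read, as all three values are limits: the limit of > 50 ug/mL in this assay, at which 1 of the 3 values shown sits. The compounds shown leave open whether the three differ at all in this assay.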